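A few compounds are considered here, and "the series" means these few. Any claim that something is new, unique, unknown or untested is made for them only; others in the source may bear on it.

For the measured compounds named here, in an ADME assay on Vero cells (Chlorocebus sabaeus) for cytotoxicity, read by MTT assay, with a stated time of 72 h (a lower number here means that less compound is tolerated, a higher number that more compound is tolerated), three compounds have numbers so far. Compound 1 `COc1ccc(/C=C(\C)C(=O)/C=C/c2ccc(F)cc2)cc1` gives 68100 nM, compound 2 `COc1ccc(/C=C(\C)C(=O)/C=C/c2ccc(Br)cc2)cc1` gives 31200 nM, and compound 3 `COc1ccc(/C=C(\C)C(=O)/C=C/c2ccc(/C=C/C(=O)/C(C)=C/c3ccc(OC)cc3)cc2)cc1` gives 460000 nM. Compound 2 therefore holds the lowest number of the three, with compound 1 its nearest neighbour and compound 3 much higher.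

Compound 4 `COc1ccc(/C=C(\C)C(=O)/C=C/c2ccccc2F)cc1` has not yet been measured. Relative to compound 2, it has 2-fluorophenyl in place of 4-bromophenyl on a double-bonded chain carbon bound to a double-bonded chain carbon.

Going by the values given here, only one measured step bears on this change, bromo in place of fluoro on an aromatic carbon, which gives a 2.2-fold lower number from compound 1 to compound 2 (0.34 log units; beyond the scatter). That step is modest but beyond the scatter. Read in reverse, it points to a modest rise in this assay when bromo gives way to fluoro. Among the compounds with values here, no measured compound carries 2-fluorophenyl, however, so the data do not show how closely compound 4 should follow compound 1, and the expectation stays loose.

The expected change is a modest rise, estimated as a 1.9-fold higher number from compound 2 to compound 4 (0.28 log units; within the scatter). For compound 4 the estimated value is 60000 nM, with an expected range of 25000 nM to 140000 nM.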

Compound 4, half-maximal cytotoxic concentration: 81200 nM
Compound 4: the middle estimate sits 1.4-fold (0.13 log units) below what was measured, within the range that was stated.
By their numbers in this assay, from the lowest: compound 2; then compounds 1 and 4 (each within the scatter of the next); then compound 3.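

In this assay, 2-fluorophenyl in place of 4-bromophenyl on a double-bonded chain carbon bound to a double-bonded chain carbon gives a 2.6-fold higher number from compound 2 to compound 4 (0.42 log units; beyond the scatter), a modest step that shows this position also responds when the halogen and its place on the ring change together. The new comparison is the one between the two fluorinated compounds, 2-fluorophenyl in place of 4-fluorophenyl giving a 1.2-fold higher number from compound 1 to compound 4 (0.08 log units; within the scatter), so in this pair the 2-fluorophenyl and 4-fluorophenyl groups cannot be told apart, and compound 2 stays separate from both. Nothing reported alongside these numbers accounts for either step.

The compounds shown leave open whether 2-bromophenyl would stand with 4-bromophenyl or with the two fluorophenyl groups, so the difference between bromo and fluoro is known here only from compound 1 and compound 2. They also leave open how plain phenyl, or a phenyl ring carrying an amine or a carboxylic acid, would stand at this same position on the chain.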